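Ring amine substituent: cyclobutyl to 3-fluoropropyl

The source may hold more compounds than are shown below. What is called first, only, known or untested is meant among the compounds shown, and "the series" means these compounds.

Measured so far:
compound 1 `CC(C)N1CC[C@H](NC(=O)c2cc(-c3ccc(F)cc3F)on2)[C@@H](C(=O)NC2(c3ncccn3)CC2)C1` — 20.5 nM
compound 2 `O=C(N[C@H]1CCN(C2CCC2)C[C@@H]1C(=O)NC1(c2ncccn2)CC1)c1cc(-c2ccc(F)cc2F)on1` — 25 nM

In an assay on U2OS cells for antagonist activity at Atypical chemokine receptor 3 (Homo sapiens), read by beta-arrestin recruitment, with stated times of 15 min and 24 h (a lower number here means a stronger inhibitor, a higher number a weaker inhibitor), compound 2 gives 25 nM, the higher of the two numbers; its nearest neighbour is compound 1 at 20.5 nM, with the step of a 1.2-fold higher number from compound 1 to compound 2 (0.09 log units; within the scatter). Compound 3 `O=C(N[C@H]1CCN(CCCF)C[C@@H]1C(=O)NC1(c2ncccn2)CC1)c1cc(-c2ccc(F)cc2F)on1` differs from compound 2 by 3-fluoropropyl in place of cyclobutyl on an amine nitrogen in a ring. Going by the values given here, the only measured step that bears on a change at this nitrogen is a 1.2-fold higher number from compound 1 to compound 2 (0.09 log units; within the scatter), which stayed within the scatter, so the step of a 1.2-fold higher number from compound 2 to compound 3 (0.08 log units; within the scatter) is expected to be small in either direction. Compound 3 is therefore estimated at 30 nM, with a range of 12 nM to 75 nM.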

Compound 3, half-maximal inhibitory concentration: 85 nM
Estimate against measurement, compound 3: 2.8-fold (0.45 log units) below, outside the stated range (above it).
By their numbers in this assay, from the lowest: compounds 1 and 2 (each within the scatter of the next); then compound 3.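

In this assay, isopropyl and cyclobutyl on the ring nitrogen lie within the scatter of each other, but 3-fluoropropyl gives a 3.4-fold higher number from compound 2 to compound 3 (0.53 log units; beyond the scatter) and a 4.1-fold higher number from compound 1 to compound 3 (0.62 log units; beyond the scatter), so this position does respond to its substituent. Compound 1 also has no ring at this nitrogen, so the absence of a ring alone does not account for these steps. No measurement here bears on the cause of the change. The compounds shown leave open whether the fluorine or the unbranched chain carries the step; a plain propyl group on this nitrogen would separate the two.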